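Amide variation from compound 2 to compound 3

This account rests on a few compounds, and the source may have more. Where it says the series, first, only, none or still open, it means among the compounds named here.

In a functional assay on the whole organism (strain Wistar) for inhibition, with Rattus norvegicus as the target, read by paw edema, with stated times of 30 min and 3 h, at a dose of 100 mg/kg by the oral route (a lower number here means less inhibition, a higher number more inhibition at the dose given (going by the name of the read-out)), compound 2 `CCCCOc1cc(C(=O)N(CC)CC)nn1-c1ccccc1` gives 44.1%, the lower of the two numbers recorded, while compound 1 `CCCCOc1cc(C(=O)NCCC)nn1-c1ccccc1` gives 51.2%; the step of a number 7.1 percentage points lower from compound 1 to compound 2 (within the scatter) stays within the scatter. Compound 3 `CCCCOc1cc(C(=O)N2CCCC2)nn1-c1ccccc1` differs from compound 2 by pyrrolidin-1-yl in place of diethylamino on a carbonyl carbon. Going by the values given here, no measured step covers a pyrrolidin-1-yl group, and the one step seen, a number 7.1 percentage points lower from compound 1 to compound 2 (within the scatter), was within the scatter, so no movement beyond the scatter is expected in this assay. For compound 3 the expected step is a number 1.9 percentage points higher from compound 2 to compound 3 (within the scatter). Compound 3 is estimated at 46%, between 30% and 62%.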

Compound 3, a percentage reported as inhibition, in the whole organism at one dose (the size of the read-out at that dose, not a potency): 17.6%
Beside the measured number, compound 3's estimate is 28.4 percentage points above it; measured number below the stated range.
By their numbers in this assay, from the lowest: compound 3; then compounds 2 and 1 (each within the scatter of the next).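

At this position on the carbonyl carbon, the amide group does move the reading in this assay: pyrrolidin-1-yl in place of diethylamino gives a number 26.5 percentage points lower from compound 2 to compound 3 (beyond the scatter), and in place of propylamino gives a number 33.6 percentage points lower from compound 1 to compound 3 (beyond the scatter). The earlier pair stayed within the scatter, so closing the two ethyl chains into a ring shows a sensitivity that the open-chain amides did not. Nothing measured bears on the reason for this step.

On these data alone, whether piperidin-1-yl or morpholin-4-yl would read like pyrrolidin-1-yl or like the open-chain amides remains open. So does the effect of a longer chain than propylamino.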